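The source may report more compounds than this note shows. Statements on the series, on what has been measured and on what is new or still open speak of the compounds shown alone.

Measured in an ADME assay on the whole organism (strain Wistar Han) for pharmacokinetics, with Rattus norvegicus as the target, at a dose of 3 umol/kg by the oral route; a lower number here means that a smaller share of the oral dose reaches the circulation, a higher number that a larger share of the oral dose reaches the circulation:

- compound 1 `CN1CCN(c2ccc(Nc3cc(-c4c[nH]c5ccccc45)ncn3)cc2)CC1`: 13%
- compound 2 `COc1cc(N2CCN(C)CC2)ccc1Nc1nccc(-c2cn(C)c3c(C)nccc23)n1`: 14%
- compound 3 `Cn1cc(-c2ccnc(-c3ccc(S(C)(=O)=O)cc3)n2)c2ccncc21`: 37%

In this assay, compound 2 gives 14%. This lies within the scatter of compound 1, while compound 3 stands higher by a margin beyond the scatter. The next compound to be tested is compound 4 `COc1cc(N2CCN(C)CC2)ccc1Nc1nccc(-c2c[nH]c3c(C)nccc23)n1`, which differs from compound 2 by one change: hydrogen in place of methyl on an aromatic nitrogen. Among the measured compounds shown here, no measured pair of compounds isolates this change, so the expectation rests on indirect evidence. Compound 1 also carries hydrogen on an aromatic nitrogen of a five-membered aromatic ring, and it gives 13%, which offers no sign of a large gain, though its core differs from that of compound 4. A small step of a number 2 percentage points lower from compound 2 to compound 4 (within the scatter) is therefore expected, one that stays within the scatter. In this assay, the estimated value for compound 4 is 12%, with an expected range of 4% to 25%.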

Compound 4, oral bioavailability: 0%
Beside the measured number, compound 4's estimate is 12 percentage points above it, outside the stated range (below it).
By their numbers in this assay, from the lowest: compound 4; then compounds 1 and 2 (each within the scatter of the next); then compound 3.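

In this assay the methyl on the aromatic nitrogen of the five-membered aromatic ring proves to matter, as hydrogen in its place gives a number 14 percentage points lower from compound 2 to compound 4 (beyond the scatter). This is the only pair shown that isolates this position, and it shows that removing a single carbon there can move the read-out by more than the usual scatter, leaving compound 4 the lowest of the series. No measurement at hand speaks to what lies behind this step.

The compounds shown leave open whether the same change has a similar effect on another core, as one pair cannot establish a pattern. They also leave open what an ethyl group or a longer chain on the same aromatic nitrogen would do to the number seen with methyl.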